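The source may report more compounds than this note shows. Statements on the series, on what has been measured and on what is new or still open speak of the compounds shown alone.

Compound 3 `O=C(COc1cccc2ccccc12)N/N=C/c1ccc(Br)cc1` carries a bromo group on an aromatic carbon of a six-membered aromatic ring of carbon only. In an ADME assay on HEL cells (Homo sapiens) for cytotoxicity (a higher number here means that more compound is tolerated, a lower number that less compound is tolerated), compound 3 gives > 100 ug/mL, which is a limit of the assay and not a number. Of the three measured values, one other is a limit too, so compound 3 cannot be ranked against it. Compound 1 `O=C(COc1cccc2ccccc12)N/N=C/c1ccc(O)cc1` carries a hydroxy group at that carbon, and in this assay compound 1 gives 20 ug/mL. Compound 2 `O=C(COc1cccc2ccccc12)N/N=C/c1ccccc1Br` gives >= 20 ug/mL in this assay, again a limit.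

Compound 4 `CSc1ccc(/C=N/NC(=O)COc2cccc3ccccc23)cc1` differs from compound 3 in one place: methylsulfanyl in place of bromo on an aromatic carbon. Within the data shown here, the only measured step at this carbon, an at least 5.0-fold higher number from compound 1 to compound 3 (0.69 log units; beyond the scatter), shows that changing the group there can move the read-out by a readable amount, though it says nothing about methylsulfanyl itself. The steps of a number no lower from compound 1 to compound 2 (the limit leaves the size open) and a step that the two limits leave unreadable from compound 2 to compound 3 cannot be read in size. The step of an at least 1.6-fold lower number from compound 3 to compound 4 (0.22 log units; that floor lies within the scatter) is expected to be modest at most. Compound 4 is expected to give 60 ug/mL in this assay, between 20 ug/mL and 150 ug/mL.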

Compound 4, minimum cytotoxic concentration: >= 100 ug/mL
Compound 4: only a limit was reported (the forecaster's own chance of this, stated with the estimate: 50%); at least 1.6-fold (0.22 log units) between middle value and limit.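

In this assay compound 4 gives >= 100 ug/mL, which is a limit of the assay and not a number. Methylsulfanyl in place of hydroxy gives an at least 5.0-fold higher number from compound 1 to compound 4 (0.69 log units; beyond the scatter), so the rise on leaving hydroxy at this carbon is not tied to bromo alone, as a second group now shows it too. The steps from compound 2 and compound 3 to compound 4 cannot be read in size, since each joins two limits: the limit of >= 100 ug/mL in this assay, at which 1 of the 4 values shown sits.

As far as these compounds go, whether methylsulfanyl or bromo is the better tolerated of the two therefore stays open, as does how far either compound lies past its limit. An amine or a carboxylic acid at this carbon could show whether hydroxy is the exception here, or whether the higher number depends on the group.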